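A few compounds are considered here, and "the series" means these few. Any claim that something is new, unique, unknown or untested is made for them only; others in the source may bear on it.

Measured in a functional assay on DU-145 cells (Homo sapiens) for inhibition, read by trypan blue exclusion, with a stated time of 96 h; on this read-out higher numbers stand for weaker inhibition of growth and lower numbers for stronger inhibition of growth:
- Compound 1 `O=C(/C(=C\c1ccc(O)cc1)SCc1ccc(Cl)cc1)c1ccc(Br)cc1`: 10000 nM
- Compound 2 `O=C(/C(=C\c1ccc(Br)cc1)SCc1ccc(Cl)cc1)c1ccc(Cl)cc1`: 1000 nM
- Compound 3 `O=C(/C(=C\c1c(O)cc(O)cc1O)SCc1ccc(Cl)cc1)c1ccc(Cl)cc1`: > 100000 nM

Compound 3 has no exact number and is known only through a limit: the limit of > 100000 nM in this assay, at which 1 of the 3 values shown sits.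

Compound 4 `O=C(/C(=C\c1ccc(O)cc1)SCc1ccc(Cl)cc1)c1ccc(Cl)cc1` has not yet been measured. The change sits on a double-bonded chain carbon bound to a double-bonded chain carbon, where 4-hydroxyphenyl takes the place of 2,4,6-trihydroxyphenyl: 4-hydroxyphenyl in place of 2,4,6-trihydroxyphenyl on a double-bonded chain carbon bound to a double-bonded chain carbon.

For the measured compounds named here, the one measured step involving this group is an at least 100-fold higher number from compound 2 to compound 3 (2.00 log units; beyond the scatter). That large step, beyond the scatter, came with the arrival of 2,4,6-trihydroxyphenyl, so its departure here is expected to bring a large move the other way, towards a lower number and stronger inhibition of growth. Compound 1 also carries 4-hydroxyphenyl and gives 10000 nM, which offers the best guide to the level expected.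

The expected change is an at least 10-fold lower number from compound 3 to compound 4 (1.00 log units; beyond the scatter).

The estimate for compound 4 is 10000 nM, with an expected range of 3000 nM to 35000 nM.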

Compound 4, concentration for 50% growth inhibition: 10000 nM
Compound 4: the middle estimate sits on the measured number at the digits printed, and the stated range covers the measured number.
By their numbers in this assay, from the lowest: compound 2; then compounds 1 and 4 (each within the scatter of the next). At a limit, above all of these: compound 3.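

In this assay, 4-hydroxyphenyl in place of 2,4,6-trihydroxyphenyl gives an at least 10-fold lower number from compound 3 to compound 4 (1.00 log units; beyond the scatter), and the true size of this step stays unknown, as one end of it is a limit: the limit of > 100000 nM in this assay, at which 1 of the 4 values shown sits.

The recovery is only partial, since hydroxy in place of bromo on an aromatic carbon gives a 10-fold higher number from compound 2 to compound 4 (1.00 log units; beyond the scatter), which places 4-hydroxyphenyl between 4-bromophenyl and 2,4,6-trihydroxyphenyl at this position. Chloro in place of bromo on an aromatic carbon gives no change at the digits printed from compound 1 to compound 4 (within the scatter), so that swap makes no visible difference here, unlike the changes on the double-bonded chain carbon.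

The compounds shown do not tell whether growth inhibition falls steadily with each added hydroxy, as no phenyl group carrying two of them appears. They also leave open how an amine or a carboxylic acid on this ring would compare with bromo.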